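The source may hold more compounds than are shown below. What is called first, only, known or untested is meant among the compounds shown, and "the series" means these compounds.

Compound 1, with structure `CC1(C)C=C(n2ccccc2=O)c2cc(C(=O)c3ccccc3)ccc2O1`, is the reference point of this pair: in a functional assay (aorta) with Rattus norvegicus as the target (on this read-out higher numbers stand for higher potency (the scale is a negative logarithm) and lower numbers for lower potency), compound 1 gives 6.61. Compound 2, `CC1(C)C=C(n2ccccc2=O)c2cc(C(=O)c3ccccc3[N+](=O)[O-])ccc2O1`, carries a nitro in place of hydrogen on an aromatic carbon and in this assay compound 2 gives 6.17. For the measured compounds named here, the single measured step, a number 0.44 log units lower from compound 1 to compound 2 (beyond the scatter), is therefore a modest loss, and compound 2 stands as the lower of the two numbers measured so far.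

Compound 3, `CC1(C)C=C(n2ccccc2=O)c2cc(C(=O)c3ccccc3C(F)(F)F)ccc2O1`, differs from compound 2 in one place: trifluoromethyl in place of nitro on an aromatic carbon. Going by the values given here, the only step that bears on this change is the one between compound 1 and compound 2, because a number 0.44 log units lower from compound 1 to compound 2 (beyond the scatter) shows what the arrival of the nitro at this carbon cost; in compound 3 that nitro leaves again, while the entering trifluoromethyl has no measured precedent. The removal of the nitro is expected to recover part of that loss, so a modest rise is estimated, a number 0.28 log units higher from compound 2 to compound 3 (within the scatter), leaving compound 3 somewhat below compound 1. For compound 3 in this assay the expected value is 6.45, with a range from 5.95 to 6.95.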

Compound 3, logarithm of the reciprocal of the active concentration, log(1/C): 6.76
Beside the measured number, compound 3's estimate is 0.31 log units below it; the range from low to high includes it.
By their numbers in this assay, from the lowest: compound 2; then compounds 1 and 3 (each within the scatter of the next).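

Swapping the nitro for trifluoromethyl on this aromatic carbon, read in this assay, gives a clear gain (a number 0.59 log units higher from compound 2 to compound 3 (beyond the scatter)), so the loss seen with the nitro does not extend to every group placed here. Set against the parent carrying hydrogen at the same carbon, the trifluoromethyl gives no readable difference (a number 0.15 log units higher from compound 1 to compound 3 (within the scatter)), which shows that this carbon, ortho to a large group, can hold a substituent with no measurable penalty, and that the 2-nitrophenyl compound is the one of the three that parts from the others. No measurement available here accounts for the different outcomes of the two groups.

The compounds shown offer only two substituents at this carbon, so they leave open how others such as a methoxy, a chlorine, an amine or a carboxylic acid would fare in this position. They also leave open whether the trifluoromethyl and the nitro would keep the same relation to each other on the remaining carbons of this ring.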